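One Chlorine Added to Compound 2

A few compounds are considered here, and "the series" means these few. Any claim that something is new, unique, unknown or untested is made for them only; others in the source may bear on it.

Compound 1, `CS(=O)(=O)CCNc1nc(-c2ccc3ncnc(Nc4ccc(F)c(Cl)c4)c3c2)cs1`: > 10000 nM
Compound 2, `CS(=O)(=O)CCNc1nc(-c2ccc3ncnc(Nc4ccc(OCc5ccccc5)cc4)c3c2)cs1`: > 18000 nM

Both measured compounds share one core and differ only in the groups carried on the ring at one end. In a functional assay on HFF cells (Homo sapiens) for inhibition (a higher number here means a weaker inhibitor, a lower number a stronger inhibitor), compound 1 gives only a limit, > 10000 nM. Compound 2 likewise reaches only a limit in this assay, > 18000 nM. Among the measured compounds shown here, compound 2 thus stands at a limit rather than at a number, and the only other value shown is a limit too.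

Compound 3, `CS(=O)(=O)CCNc1nc(-c2ccc3ncnc(Nc4ccc(OCc5ccccc5)c(Cl)c4)c3c2)cs1`, has not yet been measured. It differs from compound 2 by chloro in place of hydrogen on an aromatic carbon, in words a chloro in place of hydrogen on an aromatic carbon. Compound 1 also carries a chloro group and reaches only a limit. With nothing but limits in hand, the step from compound 2 to compound 3 is expected to bring no change beyond the scatter, a step that the limit leaves unreadable from compound 2 to compound 3. Compound 3 is therefore estimated at 20000 nM, with a likely range from 5000 nM to 100000 nM, and the assay is expected most likely to report only a limit again.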

Compound 3, half-maximal inhibitory concentration: > 30000 nM
Compound 3: a limit, no number (the forecaster's own chance of this, stated with the estimate: 80%); middle value at least 1.5-fold (0.17 log units) away from the limit.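

Among the compounds shown here, compound 3, like compound 1 and compound 2, gives only a limit in this assay, so no step from compound 1 or compound 2 to compound 3 can be read. The compounds shown leave open how strongly each inhibits, and whether chloro in place of hydrogen changes that at all.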